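This account rests on a few compounds, and the source may have more. Where it says the series, first, only, none or still open, it means among the compounds named here.

Working notes on the series. Compound 1 `CCOC(=O)C1=Cc2ccccc2OC1(OCc1cc(-c2ccc(C)cc2)no1)C(F)(F)F` carries the ethyl ester and a 4-methylphenyl group. In a functional assay on A549 cells (Homo sapiens) for inhibition, read by MTT assay, with a stated time of 24 h (a higher number here means a weaker inhibitor, a lower number a stronger inhibitor), compound 1 gives > 150000 nM, which is a limit of the assay and not a number; this is the limit described at the limit of > 150000 nM in this assay, at which 1 of the 3 values shown sits. Compound 2 `Cc1ccc(-c2cc(COC3(C(F)(F)F)Oc4ccccc4C=C3C(=O)O)on2)cc1` differs from compound 1 by hydrogen in place of ethyl on an oxygen next to a carbonyl group, and in this assay compound 2 gives 51200 nM. That step is an at least 2.9-fold lower number from compound 1 to compound 2 (0.46 log units; beyond the scatter). Within the data shown here, compound 3 `CCOC(=O)C1=Cc2ccccc2OC1(OCc1cn(-c2ccc(F)c([N+](=O)[O-])c2)nn1)C(F)(F)F`, with a nitro-bearing phenyl on a different five-membered ring, gives 11900 nM in this assay; no single-change step links it to compound 1, so the two values only stand side by side.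

Compound 4 `CCOC(=O)C1=Cc2ccccc2OC1(OCc1cc(-c2ccc([N+](=O)[O-])cc2)no1)C(F)(F)F` is not yet measured. It differs from compound 1 by nitro in place of methyl on an aromatic carbon, para to a large group. Among the measured compounds shown here, no measured step covers this change, and compound 1 sits only at a limit, so the size of the move cannot be anchored. Compound 4 is expected to come out at 60000 nM, between 15000 nM and 200000 nM. That estimate corresponds to an expected step of an at least 2.5-fold lower number from compound 1 to compound 4 (0.39 log units; beyond the scatter).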

Compound 4, half-maximal inhibitory concentration: > 150000 nM
Compound 4 was reported as a limit; the forecaster's own chance of this, stated with the estimate: 35%; middle value at least 2.5-fold (0.39 log units) away from the limit.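

The step from compound 1 to compound 4 cannot be read, as both values are limits of the assay and not numbers: the limit of > 150000 nM in this assay, at which 2 of the 4 values shown sit.

In this assay the compounds shown leave open how far 4-nitrophenyl and 4-methylphenyl differ on the shared core.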